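A ring swap on compound 3 and its clearance

A few compounds are considered here, and "the series" means these few. Any claim that something is new, unique, unknown or untested is made for them only; others in the source may bear on it.

Compounds that share one core can differ in how fast liver enzymes clear them. In an ADME assay on microsomes from liver (Homo sapiens) for metabolic stability, read by LC-MS, using NADPH, with a stated time of 30 min, tested at 1 uM (on this read-out higher numbers stand for fast clearance and lower numbers for slow clearance), compound 1 `CC(C)c1noc(N2CCC(Oc3cc(N4CCc5cc(N6CCCNS6(=O)=O)ccc54)ncn3)CC2)n1` gives 79 mL.min-1.g-1. Compound 2 `CC(C)c1noc(N2CCC(Oc3cc(N4CCc5cc(N6CCCS6(=O)=O)ccc54)ncn3)CC2)n1` gives 18 mL.min-1.g-1, and compound 3 `CC(C)c1noc(N2CCC(Oc3cc(N4CCc5cc(N6CCOCC6=O)ccc54)ncn3)CC2)n1` gives 27 mL.min-1.g-1. These last two values cannot be told apart, as a 1.5-fold higher number from compound 2 to compound 3 (0.18 log units; within the scatter) shows. Both lie clear of the first value, with a 4.4-fold lower number from compound 1 to compound 2 (0.64 log units; beyond the scatter) and a 2.9-fold lower number from compound 1 to compound 3 (0.47 log units; beyond the scatter).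

Compound 4 `CC(C)c1noc(N2CCC(Oc3cc(N4CCc5cc(N6CCC(O)CC6=O)ccc54)ncn3)CC2)n1` keeps the core but carries 4-hydroxy-2-oxopiperidin-1-yl in place of 3-oxomorpholin-4-yl on an aromatic carbon. Within the data shown here, no measured pair shows this exact exchange. The closest guide is other exchanges at this place, which were modest at most, the largest being a 4.4-fold lower number from compound 1 to compound 2 (0.64 log units; beyond the scatter). The swap between two similar rings gave only a 1.5-fold higher number from compound 2 to compound 3 (0.18 log units; within the scatter). A step beyond the scatter in this assay is therefore not expected, in either direction. The expected step is a 1.1-fold lower number from compound 3 to compound 4 (0.05 log units; within the scatter). The estimated clearance of compound 4 is 24 mL.min-1.g-1, with an expected range from 11 mL.min-1.g-1 to 50 mL.min-1.g-1.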

Compound 4, intrinsic clearance in microsomes: 4 mL.min-1.g-1
Beside the measured number, compound 4's estimate is 6.0-fold (0.78 log units) above it, and the stated range ends above it.
By their numbers in this assay, from the lowest: compound 4; then compounds 2 and 3 (each within the scatter of the next); then compound 1.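

Among the groups at this place on the aromatic carbon, 4-hydroxy-2-oxopiperidin-1-yl gives the slowest clearance so far in this assay, with a 6.8-fold lower number from compound 3 to compound 4 (0.83 log units; beyond the scatter), a 4.5-fold lower number from compound 2 to compound 4 (0.65 log units; beyond the scatter) and a 20-fold lower number from compound 1 to compound 4 (1.30 log units; beyond the scatter), the last being the only large step in the set. The position can therefore respond strongly even when one six-membered non-aromatic ring replaces another, a change that also adds a hydrogen-bond donor absent from 3-oxomorpholin-4-yl. Nothing measured here explains the drop.

From the compounds shown here alone, the hydroxy group and the loss of the ring oxygen arrive together in compound 4, and their separate shares in the step stay open. Also open, going by these compounds, is how a plain 2-oxopiperidin-1-yl ring, or an amine or methoxy group in place of the hydroxy group, would behave.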